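The compounds below may be only part of what the source reports. "The series", "measured", "known", "first", "only" and "open" are said of these compounds alone.

Measured in a physicochemical assay for lipophilicity, using the shake flask method, measured as octanol-water partition, with a stated time of 30 min, at pH 7.4; a lower number here means a more polar compound, a higher number a more lipophilic compound:
- compound 1 `Cc1nn(-c2ccccn2)c2cc(-c3ccc(CCC(=O)O)cc3)ncc12`: 1.6
- compound 2 `O=C(O)CCc1ccc(-c2ccc3cnn(-c4ccccn4)c3c2)cc1`: 2.4

Compound 2 stands highest of the two, and its gap to compound 1 lies beyond the usual scatter. Compound 3 `COc1nn(-c2ccccn2)c2cc(-c3ccc(CCC(=O)O)cc3)ccc12` has not yet been measured. It differs from compound 2 by methoxy in place of hydrogen on an aromatic carbon, with methoxy in place of hydrogen on an aromatic carbon. Within the data shown here, no measured pair shows this change, so the expectation rests on the structural change alone. A small rise in this assay is expected, possibly no larger than the scatter, and the expected step is a number 0.20 log units higher from compound 2 to compound 3 (within the scatter). For compound 3 the estimated value is 2.6, with an expected range of 2.1 to 3.1.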

Compound 3, distribution coefficient: 3.3
Compound 3: middle estimate off by 0.70 log units, on the low side, and the stated range ends below it.
By their numbers in this assay, from the lowest: compound 1; then compound 2; then compound 3.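

Methoxy in place of hydrogen on an aromatic carbon of the five-membered aromatic ring, next to the ring nitrogen, gives a number 0.90 log units higher from compound 2 to compound 3 (beyond the scatter) in this assay, so this carbon is a place where a single change moves the read-out. Compound 1 and compound 2 differ in more than one place, which leaves this pair as the only one that isolates a single position. Nothing shown here accounts for the size of the step.

Going by these compounds, whether an ethoxy group, a hydroxyl or an amine on the same carbon would shift the number in the same way stays open. So does whether methoxy would give a similar step on the core of compound 1.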